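Bornyl esters: swapping the amine on the carbonyl-bound carbon

The source may hold more compounds than are shown below. What is called first, only, known or untested is meant among the compounds shown, and "the series" means these compounds.

Compound 3 `CN1CCN(CC(=O)O[C@@H]2C[C@@H]3CC[C@@]2(C)C3(C)C)CC1` sits second highest of the three numbers in an ADME assay on MDCK cells (Canis lupus familiaris) for cytotoxicity, read by MTT assay, with a stated time of 48 h (on this read-out lower numbers stand for higher toxicity in this test and higher numbers for lower toxicity in this test), giving 103000 nM; compound 1 `CC1(C)[C@H]2CC[C@]1(C)[C@H](OC(=O)CN1CCCCC1)C2` gives 138000 nM, and compound 2 `CN1CCN(CCC(=O)O[C@@H]2C[C@@H]3CC[C@@]2(C)C3(C)C)CC1` gives 48100 nM. Compound 4 `CC1(C)[C@H]2CC[C@]1(C)[C@H](OC(=O)CCN1CCCC1)C2` differs from compound 3 by (pyrrolidin-1-yl)methyl in place of 4-methylpiperazin-1-yl on a saturated chain carbon bound to a carbonyl carbon. Among the measured compounds shown here, the one measured step that bears on an amine swap, a 1.3-fold lower number from compound 1 to compound 3 (0.13 log units; within the scatter), was small. Compound 2 and compound 3 share the same amine yet differ in the chain, and the values of compound 2 and compound 3 show a lower number for the longer chain. Compound 4 carries the longer chain, so a modestly lower number than compound 3 is expected, roughly a 1.7-fold lower number from compound 3 to compound 4 (0.23 log units; within the scatter). For compound 4 the expected value in this assay is 60000 nM, with a range from 25000 nM to 140000 nM.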

Compound 4, half-maximal cytotoxic concentration: 125000 nM
For compound 4 the middle estimate is 2.1-fold (0.32 log units) below the measured one, and the stated range covers the measured number.
By their numbers in this assay, from the lowest: compound 2; then compounds 3, 4 and 1 (each within the scatter of the next).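

In this assay, pyrrolidin-1-yl in place of 4-methylpiperazin-1-yl on a saturated chain carbon, two bonds along the chain from a carbonyl carbon, gives a 2.6-fold higher number from compound 2 to compound 4 (0.41 log units; beyond the scatter), so the longer chain does not go with the lower number on its own. The exchanges on a saturated chain carbon bound to a carbonyl carbon, a 1.2-fold higher number from compound 3 to compound 4 (0.08 log units; within the scatter) and a 1.1-fold lower number from compound 1 to compound 4 (0.04 log units; within the scatter), stay small. Nothing available explains this difference. From the compounds shown here alone, whether a morpholine on either chain, or a still longer chain, would fall with compound 2 or with compound 4 remains open.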